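The compounds below may be only part of what the source reports. "The series", "measured", "known", "first", "only" and "open" are said of these compounds alone.

Working notes on the series around compound 3 `CN(CC(=O)N1CCc2ccccc2C1)C(=O)c1ccc(S(C)(=O)=O)c([N+](=O)[O-])c1`. In an ADME assay on HepG2 cells (Homo sapiens) for cytotoxicity, read by CellTiter-Glo and ATP content, with a stated time of 72 h (a higher number here means that more compound is needed for the effect, a lower number that less compound is needed), compound 3 gives > 27000 nM, which is a limit of the assay and not a number. Compound 1 `CCCN(C(=O)CN(C)C(=O)c1ccc(S(C)(=O)=O)c([N+](=O)[O-])c1)c1ccccc1` is recorded in this assay at > 27000 nM, likewise a limit. Compound 2 `CN(Cc1cccc(F)c1)C(=O)CN(C)C(=O)c1ccc(S(C)(=O)=O)c([N+](=O)[O-])c1` shows in this assay a value of > 27000 nM, again a limit. Within the data shown here, compound 3 therefore stands exactly where the rest of the measured set stands, since every value so far sits at the limit of > 27000 nM in this assay, at which 3 of the 3 values shown sit.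

Compound 4 `CS(=O)(=O)c1ccc(C(=O)NCC(=O)N2CCc3ccccc3C2)cc1[N+](=O)[O-]` differs from compound 3 by hydrogen in place of methyl on an amide-type nitrogen. The measured steps that could inform this change are a step that the two limits leave unreadable from compound 1 to compound 2, a step that the two limits leave unreadable from compound 1 to compound 3 and a step that the two limits leave unreadable from compound 2 to compound 3; none has a readable size, so they only show that substitution on the carbonyl carbon of this series has not moved any value off the limit. No step beyond the scatter is expected here in this assay either. Compound 4 is expected to give 30000 nM, with a range from 14000 nM to 65000 nM, and the estimated step that the limit leaves unreadable from compound 3 to compound 4 most likely ends again as a limit.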

Compound 4, half-maximal effective concentration: > 27000 nM
Compound 4 ended at the assay's limit (the forecaster's own chance of this, stated with the estimate: 85%); the middle value does not contradict the limit.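

No new step can be read from compound 3 to compound 4 in this assay, since both results are limits and not numbers: the limit of > 27000 nM in this assay, at which 4 of the 4 values shown sit.

The compounds shown leave open what concentration any of them needs for the effect, and which change would bring a value off the limit.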